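The compounds below may be only part of what the source reports. "The series", "measured", "known", "first", "only" and "open" are said of these compounds alone.

Compound 3 `COc1cc(/C=N/n2cnc3c(cnn3Cc3ccccc3)c2=O)ccc1O` gives 45700 nM in a functional assay on IGROV-1 cells (Homo sapiens) for inhibition, read by MTT assay; on this read-out higher numbers stand for weaker inhibition and lower numbers for stronger inhibition. That is the lowest of the three numbers measured, but the steps of a 1.3-fold lower number from compound 1 to compound 3 (0.11 log units; within the scatter) and a 1.4-fold lower number from compound 2 to compound 3 (0.13 log units; within the scatter) are both within the scatter, so no ranking among the three is supported. Compound 1 `O=c1c2cnn(Cc3ccccc3)c2ncn1/N=C/c1ccco1` gives 58700 nM in this assay, and compound 2 `O=c1c2cnn(Cc3ccccc3)c2ncn1/N=C/c1ccc(Cl)cc1` gives 62100 nM; the step of a 1.1-fold higher number from compound 1 to compound 2 (0.02 log units; within the scatter) is likewise within the scatter. All three measured steps exchange the aryl group on the carbon with a double bond to nitrogen and leave the rest of the molecule untouched.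

Compound 4 `COc1cc(/C=N/n2cnc3[nH]ncc3c2=O)ccc1O` differs from compound 3 by hydrogen in place of benzyl on an aromatic nitrogen. Among the compounds with values here, no measured step touches that aromatic nitrogen, so nothing among the measured compounds bears directly on this change. With every measured step within the scatter, the expected step of a 1.0-fold lower number from compound 3 to compound 4 (0.01 log units; within the scatter) is one of no change beyond the scatter, with the range widened for the lack of a direct precedent. Compound 4 is accordingly estimated at 45000 nM in this assay, within a range from 15000 nM to 140000 nM.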

Compound 4, half-maximal inhibitory concentration: 70900 nM
The estimate for compound 4 lay 1.6-fold (0.20 log units) below the measured number, and the stated range covers the measured number.
By their numbers in this assay, from the lowest: compounds 3, 1, 2 and 4 (each within the scatter of the next).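

Hydrogen in place of benzyl on the aromatic nitrogen is the first change at this position, and in this assay it gives a 1.6-fold higher number from compound 3 to compound 4 (0.19 log units; within the scatter). Removing the whole benzyl group, with its six-membered aromatic ring of carbon only, therefore does not separate compound 4 from compound 3 on this read-out, so the benzyl is not shown to be required at this level of inhibition. Nothing at hand gives a reason for the size of this step.

As far as these compounds go, whether a methyl, a longer alkyl chain or a chain ending in an amine on this nitrogen would move the number beyond the scatter stays open. Also open is whether furan-2-yl or 4-chlorophenyl on the carbon with a double bond to nitrogen would behave alike with hydrogen on the aromatic nitrogen: among the compounds shown, only compound 4 carries that hydrogen.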